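The compounds below may be only part of what the source reports. "The series", "measured", "known", "first", "only" and "open" are said of these compounds alone.

Compound 2 `COc1ccc(CNc2nc3cc(N)cc(N)c3nc2-c2ccccc2)cc1OC` stands second highest of the three numbers in a functional assay on SF-268 cells (Homo sapiens) for inhibition, read by sulforhodamine B assay, with a stated time of 48 h (on this read-out lower numbers stand for stronger inhibition of growth and higher numbers for weaker inhibition of growth), where compound 2 gives 14800 nM; compound 1 `Nc1cc(N)c2nc(-c3ccccc3)c(NCc3ccc(Cl)c(Cl)c3)nc2c1` gives 20000 nM and compound 3 `COc1cc(CNc2nc3cc(N)cc(N)c3nc2-c2ccccc2)cc(OC)c1OC` gives 2950 nM. Compound 4 `COc1ccc(CNc2nc3cc(N)cc(N)c3nc2-c2ccccc2)cc1` differs from compound 2 by hydrogen in place of methoxy on an aromatic carbon. The measured step that bears on this change is its reverse, a 5.0-fold lower number from compound 2 to compound 3 (0.70 log units; beyond the scatter), in which a methoxy enters on an aromatic carbon of the same ring; the other step, a 1.4-fold lower number from compound 1 to compound 2 (0.13 log units; within the scatter), exchanges the whole aryl group and carries less weight here. Compound 4 is therefore expected to give a higher number in this assay, by roughly a 2.0-fold higher number from compound 2 to compound 4 (0.31 log units; beyond the scatter). The value expected for compound 4 is 30000 nM, with a range from 10000 nM to 80000 nM.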

Compound 4, concentration for 50% growth inhibition: 9770 nM
For compound 4 the middle estimate is 3.1-fold (0.49 log units) above the measured one; measured number outside the range, below it.
By their numbers in this assay, from the lowest: compound 3; then compounds 4, 2 and 1 (each within the scatter of the next, the first and the last beyond it).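

In this assay, replacing 3,4-dimethoxyphenyl with 4-methoxyphenyl gives a 1.5-fold lower number from compound 2 to compound 4 (0.18 log units; within the scatter), so hydrogen and methoxy cannot be told apart at this aromatic carbon, and this change does not mirror a 5.0-fold lower number from compound 2 to compound 3 (0.70 log units; beyond the scatter). Replacing 3,4-dichlorophenyl with 4-methoxyphenyl gives a 2.0-fold lower number from compound 1 to compound 4 (0.31 log units; beyond the scatter), a modest step beyond the scatter, unlike the exchange for 3,4-dimethoxyphenyl. No supporting data bear on these steps. Open, going by these compounds, is whether a hydroxyl or an amine on this same carbon would separate from hydrogen and methoxy in this assay.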